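1H-pyrrol-1-yl in place of 2-methylpiperidin-1-yl

A few compounds are considered here, and "the series" means these few. Any claim that something is new, unique, unknown or untested is made for them only; others in the source may bear on it.

Compound 1 `CN(C)c1nc(Cc2c(F)cccc2F)cc(=O)[nH]1` reads > 94000 nM in an ADME assay on MT4 cells (Homo sapiens) for cytotoxicity, read by MTT assay, with a stated time of 4 days (a higher number here means that more compound is tolerated, a lower number that less compound is tolerated), and this is a limit of the assay. Compound 2 `CCCN(C)c1nc(Cc2c(F)cccc2F)cc(=O)[nH]1` gives a true number, 85000 nM. Among the measured compounds shown here, the one readable step, an at least 1.1-fold lower number from compound 1 to compound 2 (0.04 log units; that floor lies within the scatter), stays within the scatter. Compound 3 `CC1CCCCN1c1nc(Cc2c(F)cccc2F)cc(=O)[nH]1` stands at > 78000 nM, which is again a limit. Neither a step that the two limits leave unreadable from compound 1 to compound 3 nor a step that the limit leaves unreadable from compound 2 to compound 3 yields a size, so compound 3 has no exact position in this assay.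

Compound 4 `O=c1cc(Cc2c(F)cccc2F)nc(-n2cccc2)[nH]1` differs from compound 3 as follows: 1H-pyrrol-1-yl in place of 2-methylpiperidin-1-yl on an aromatic carbon. For the measured compounds named here, no measured step brings an aromatic ring onto this carbon, so the series offers no direct precedent. Going by the values given here, with compound 2 at 85000 nM as the only number, and the step to it within the scatter, no step beyond the scatter is expected in this assay. The expected change is an at least 1.1-fold lower number from compound 3 to compound 4 (0.04 log units; that floor lies within the scatter). The estimate for compound 4 is 70000 nM, with an expected range of 25000 nM to 120000 nM.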

Compound 4, half-maximal cytotoxic concentration: > 87000 nM
Compound 4: a limit, no number; the forecaster's own chance of this, stated with the estimate: 55%; at least 1.2-fold (0.09 log units) between middle value and limit.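

In this assay, among the compounds shown here, the aromatic 1H-pyrrol-1-yl ring is the first aromatic group on this carbon, between two ring nitrogen atoms, and the one readable step is an at least 1.0-fold higher number from compound 2 to compound 4 (0.01 log units; that floor lies within the scatter), which does not separate the two compounds. The steps from compound 1 and from compound 3 to compound 4 cannot be read. Compound 4 gives a limit and not a number: the limit of > 87000 nM in this assay, at which 1 of the 4 values shown sits.

From the compounds shown here alone, the true values of compound 1, compound 3 and compound 4 remain unknown, so no order among them can be given. Also open, going by these compounds, is whether a carboxylic acid, a primary amine or a phenyl ring on this aromatic carbon would give a true number in this assay that lies beyond the scatter from compound 2.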